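Replacing a sulfur Linker by a Benzylamine in Compound 2

The compounds below may be only part of what the source reports. "The series", "measured", "known", "first", "only" and "open" are said of these compounds alone.

Measured compounds:
- compound 1, `CCOC(=O)[C@H](CCC(=O)O)NC(=O)c1ccc(Sc2nc3cc(N)cc(N)c3nc2-c2ccccc2)cc1`: 39800 nM
- compound 2, `Nc1cc(N)c2nc(-c3ccccc3)c(Sc3ccc(F)cc3)nc2c1`: 34700 nM

The two compounds share a core carrying two amino groups and a phenyl group. In a functional assay on OVCAR-8 cells (Homo sapiens) for inhibition, read by sulforhodamine B assay, with a stated time of 48 h (a lower number here means a stronger inhibitor of growth, a higher number a weaker inhibitor of growth), compound 1 gives 39800 nM. In this assay compound 2 gives 34700 nM. The two numbers sit within the scatter of each other, so neither compound can be called the stronger inhibitor of growth; both are weak.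

Compound 3, `Nc1cc(N)c2nc(-c3ccccc3)c(NCc3ccc(F)cc3)nc2c1`, has not yet been measured. It differs from compound 2 in one place: (4-fluorobenzyl)amino in place of (4-fluorophenyl)sulfanyl on an aromatic carbon. The linker that joins the fluorinated ring to the core is therefore rebuilt, gaining one hydrogen-bond donor. Among the measured compounds shown here, no measured pair shows what such a change does on this core, so no direction can be read from the data.

With nothing to point either way, compound 3 is expected to stay near compound 2, and the step of a 1.0-fold higher number from compound 2 to compound 3 (0.00 log units; within the scatter) is expected to lie within the scatter. The estimate for compound 3 in this assay is 35000 nM, with a range from 9000 nM to 130000 nM.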

Compound 3, concentration for total growth inhibition: 6030 nM
Beside the measured number, compound 3's estimate is 5.8-fold (0.76 log units) above it; the measured number lies below the stated range.
By their numbers in this assay, from the lowest: compound 3; then compounds 2 and 1 (each within the scatter of the next).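

In this assay, putting (4-fluorobenzyl)amino in place of (4-fluorophenyl)sulfanyl on this aromatic carbon, next to the ring nitrogen, gives a 5.8-fold lower number from compound 2 to compound 3 (0.76 log units; beyond the scatter). This shows that the linker joining the fluorinated ring to the shared core affects growth inhibition, something the two earlier numbers, within the scatter of each other, could not reveal. Nothing available explains the gain, and the swap alters several things at once: sulfur leaves, a nitrogen bearing a hydrogen-bond donor enters, and the linker grows longer.

The data therefore cannot say whether the nitrogen or the longer linker matters more; a (4-fluorophenyl)amino group would keep the nitrogen on the shorter linker, and a (4-fluorobenzyl)sulfanyl group would keep the sulfur on the longer one. Going by these compounds, it also remains open whether the fluorine contributes to the gain, which a plain benzylamino group would test, and whether an N-methyl-N-(4-fluorobenzyl)amino group, with no hydrogen on the linker nitrogen, would hold the lower number of compound 3.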